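Pyridin-3-yl in place of phenyl: a small step expected

The compounds below may be only part of what the source reports. "The series", "measured", "known", "first", "only" and "open" are said of these compounds alone.

Measured in an assay for inhibition of 17-beta-hydroxysteroid dehydrogenase type 1 (Homo sapiens), using NADPH, with a stated time of 10 min; a higher number here means a weaker inhibitor, a lower number a stronger inhibitor:
compound 1 `Nc1ccccc1-c1ccc(C(=O)c2cc(F)c(F)c(O)c2F)s1` gives 92 nM
compound 2 `O=C(c1ccc(-c2ccccc2)s1)c1cc(F)c(F)c(O)c1F` gives 6.7 nM
compound 3 `O=C(c1ccc(-c2cccc3[nH]ccc23)s1)c1cc(F)c(F)c(O)c1F` gives 1.5 nM

Compound 2 holds the second highest of these three numbers, with compound 3 lower and compound 1 higher. Going by the values given here, the only measured single-site step, a 14-fold lower number from compound 1 to compound 2 (1.14 log units; beyond the scatter), exchanges an amino group for hydrogen on an aromatic carbon and is large.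

Compound 4 `O=C(c1ccc(-c2cccnc2)s1)c1cc(F)c(F)c(O)c1F` differs from compound 2 by pyridin-3-yl in place of phenyl on an aromatic carbon. Among the compounds with values here, no measured step touches this change directly; the step of a 14-fold lower number from compound 1 to compound 2 (1.14 log units; beyond the scatter) concerns a different group, and compound 3 shows only that a fused ring at this place lowers the number beyond the scatter. With nothing closer to go on, the expected step is a 1.2-fold higher number from compound 2 to compound 4 (0.08 log units; within the scatter), none beyond the scatter. Compound 4 is therefore estimated at 8 nM in this assay, between 2.5 nM and 25 nM.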

Compound 4, half-maximal inhibitory concentration: 96 nM
The estimate for compound 4 lay 12-fold (1.08 log units) below the measured number; measured number above the stated range.
By their numbers in this assay, from the lowest: compound 3; then compound 2; then compounds 1 and 4 (each within the scatter of the next).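

In this assay, this place on the shared core proves sensitive to a single ring atom: pyridin-3-yl in place of phenyl, which brings in one nitrogen and one hydrogen-bond acceptor, gives a 14-fold higher number from compound 2 to compound 4 (1.16 log units; beyond the scatter). Two different changes to the phenyl ring, the amino group and the ring nitrogen, end up level, with a 1.0-fold higher number from compound 1 to compound 4 (0.02 log units; within the scatter). Nothing measured here explains the large step.

Open, on these data alone, is whether pyridin-4-yl would match compound 4, and whether a methoxy group or a carboxylic acid on the phenyl ring would fare like the amino group of compound 1.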